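The source may report more compounds than this note shows. Statements on the series, on what has been measured and on what is new or still open speak of the compounds shown alone.

Measured in a functional assay on HeLa cells (Homo sapiens) for antiproliferative activity, read by CCK-8 assay, with a stated time of 72 h; on this read-out higher numbers stand for weaker inhibition of growth and lower numbers for stronger inhibition of growth:
- compound 1 `CCC1C(=O)N(C)c2cnc(-n3ccc4cc(C(=O)NC(C)C)ccc43)nc2N1c1ccn(C)n1`: 4350 nM
- compound 2 `CCCNC(=O)c1ccc2c(ccn2-c2ncc3c(n2)N(c2ccn(C)n2)C(CC)C(=O)N3C)c1`: 6160 nM
- compound 3 `CCC1C(=O)N(C)c2cnc(-n3ccc4cc(C(=O)NC5CCCC5)ccc43)nc2N1c1ccn(C)n1`: 27400 nM

Compound 3 has the highest number of the three, and so the weakest inhibition of growth in this assay. The next compound is compound 4 `CCC1C(=O)N(C)c2cnc(-n3ccc4cc(C(N)=O)ccc43)nc2N1c1ccn(C)n1`, with hydrogen in place of cyclopentyl on an amide-type nitrogen. Carbamoyl thus replaces cyclopentylcarbamoyl.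

Going by the values given here, two measured steps bear most directly on this change: a 6.3-fold higher number from compound 1 to compound 3 (0.80 log units; beyond the scatter) and a 4.4-fold higher number from compound 2 to compound 3 (0.65 log units; beyond the scatter). A third, a 1.4-fold higher number from compound 1 to compound 2 (0.15 log units; within the scatter), does not separate propyl from isopropyl. Among the compounds with values here, no compound with the amide hydrogen has been measured, so any expectation is an extrapolation. With cyclopentyl gone, compound 4 is expected to move back toward compound 2 at 6160 nM, though not necessarily all the way. The expected step, toward a lower number, is a 3.0-fold lower number from compound 3 to compound 4 (0.48 log units; beyond the scatter). For compound 4 the estimated value is 9000 nM. The expected range for compound 4 runs from 3000 nM to 30000 nM.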

Compound 4, concentration for 50% growth inhibition: 27400 nM
Compound 4: middle estimate off by 3.0-fold (0.48 log units), on the low side, within the range that was stated.
By their numbers in this assay, from the lowest: compounds 1 and 2 (each within the scatter of the next); then compounds 3 and 4 (each within the scatter of the next).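

In this assay hydrogen in place of cyclopentyl on the amide-type nitrogen gives no change at the digits printed from compound 3 to compound 4 (within the scatter) and so does not recover the level of the propyl and isopropyl amides. Against those two amides, the amide hydrogen gives a 4.4-fold higher number from compound 2 to compound 4 (0.65 log units; beyond the scatter) and a 6.3-fold higher number from compound 1 to compound 4 (0.80 log units; beyond the scatter), so among these four compounds the number does not follow the carbon count on this nitrogen: propyl and isopropyl stand lower, while the group with no carbon and the group with the most carbon stand together at the higher level. Nothing measured for these compounds accounts for this result.

Open, from the compounds shown here alone, is whether methyl or ethyl on this nitrogen would fall with compounds 1 and 2 or with compounds 3 and 4. Also open, going by these compounds, is how a butyl chain, a chain ending in an amine, or a carboxylic acid in place of the carbamoyl would read.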